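This account rests on a few compounds, and the source may have more. Where it says the series, first, only, none or still open, it means among the compounds named here.

Going by the values given here, in a physicochemical assay for solubility (a higher number here means a more soluble compound, a lower number a less soluble compound), compound 2 `CNC(=O)c1cccn(Cc2ccccc2)c1=O` gives 78 ug/mL, and this is the only value that is reported as an outright number. Compound 1 `CNC(=O)c1cc(C(=O)NC2CC2)cn(Cc2ccc(F)cc2)c1=O` is reported in this assay at >= 162 ug/mL, which is a limit of the assay and not a number. Compound 3 `CNC(=O)c1cc(C(=O)NC2CC2)cn(Cc2cccc([C@@H](C)O)c2)c1=O` is reported in this assay at >= 131 ug/mL, again a limit rather than a number. The step that the two limits leave unreadable from compound 1 to compound 3 is therefore of unreadable size, since both ends sit at limits, one at the limit of >= 162 ug/mL in this assay, at which 1 of the 3 values shown sits, and the other at the limit of >= 131 ug/mL in this assay, at which 1 of the 3 values shown sits.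

Compound 4 `CNC(=O)c1cc(C(=O)NCCOC)cn(Cc2ccccc2)c1=O` differs from compound 2 by (2-methoxyethyl)carbamoyl in place of hydrogen on an aromatic carbon. Among the compounds with values here, no measured step changes the same position, so the one measured step, being unreadable, gives no direct guide, and what can be said is only that compound 2 holds the one number while the two compounds that carry a carbamoyl group at that aromatic carbon both reach a limit. On that basis compound 4 is expected to remain at or somewhat above the value of compound 2, an estimated 120 ug/mL with a range from 50 ug/mL to 260 ug/mL. The expected step of a 1.5-fold higher number from compound 2 to compound 4 (0.19 log units; within the scatter) is thus estimated as modest and possibly within the scatter.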

Compound 4, solubility: >= 164 ug/mL
Compound 4 gave a limit, no number; the forecaster's own chance of this, stated with the estimate: 30%; middle value at least 1.3-fold (0.13 log units) away from the limit.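

Going by these compounds alone, this result gives the first readable step at this aromatic carbon, which is two atoms from the ring nitrogen. Until now the only step shown could not be read, and compound 1 and compound 3 each differ from compound 2 in more than one place. With (2-methoxyethyl)carbamoyl in place of hydrogen and nothing else changed, this assay now shows an at least 2.1-fold higher number from compound 2 to compound 4 (0.32 log units; beyond the scatter), so a single change at this position is enough to carry the read-out beyond the scatter, and the reading for compound 4 is a limit rather than a number: the limit of >= 164 ug/mL in this assay, at which 1 of the 4 values shown sits.

From the compounds shown here alone, the true size of this step remains open, as the data give it a lower bound and no upper end, and nothing here separates the contribution of the amide from that of the methoxyethyl chain. Also open, going by these compounds, is whether a carboxylic acid, a chain ending in an amine or a longer ether chain at this aromatic carbon would give a step of similar size, and whether the step would hold with a substituted benzyl group on the ring nitrogen.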